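Compound 2 to compound 4: fluoro replaces ethyl

A few compounds are considered here, and "the series" means these few. Any claim that something is new, unique, unknown or untested is made for them only; others in the source may bear on it.

In a functional assay on A549 cells (Homo sapiens) for inhibition, read by MTT assay, with a stated time of 48 h (on this read-out lower numbers stand for stronger inhibition and higher numbers for weaker inhibition), compound 1 (`O=C(Nc1cccc(Cl)c1)Nc1ccc(-c2cc(=O)c3ccccc3o2)c(Cl)c1`) gives 14000 nM. Compound 2 (`CCc1ccc2oc(-c3ccc(NC(=O)Nc4cccc(Cl)c4)cc3Cl)cc(=O)c2c1`) stands only at a limit of the assay, > 50000 nM. Compound 3 (`CCc1ccc2oc(-c3ccc(NC(=O)Nc4ccc(Cl)cc4)cc3Cl)cc(=O)c2c1`) also stands only at a limit, > 50000 nM. Compound 4 (`O=C(Nc1cccc(Cl)c1)Nc1ccc(-c2cc(=O)c3cc(F)ccc3o2)c(Cl)c1`) differs from compound 2 as follows: fluoro in place of ethyl on an aromatic carbon. The ethyl step bears most directly: an at least 3.5-fold higher number from compound 1 to compound 2 (0.55 log units; beyond the scatter). The chlorophenyl step adds nothing on size: a step that the two limits leave unreadable from compound 2 to compound 3. Compound 4 carries no ethyl, so a lower number than the limit is expected in this assay, of at least modest size. The expected change is an at least 2.5-fold lower number from compound 2 to compound 4 (0.39 log units; beyond the scatter). For compound 4 the estimate is 20000 nM, with an expected range of 7000 nM to 50000 nM.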

Compound 4, half-maximal inhibitory concentration: > 50000 nM
Compound 4 ended at the assay's limit (the forecaster's own chance of this, stated with the estimate: 25%); at least 2.5-fold (0.39 log units) between middle value and limit.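

Fluoro in place of hydrogen at this aromatic carbon gives an at least 3.5-fold higher number from compound 1 to compound 4 (0.55 log units; beyond the scatter) in this assay, so the higher number is not confined to ethyl: a single fluorine atom is enough, and no substituent shown at this carbon keeps the number of the unsubstituted compound 1. The steps from compound 2 to compound 3 and from compound 2 to compound 4 cannot be read, as both ends of each are limits. The series mostly sits at one ceiling: the limit of > 50000 nM in this assay, at which 3 of the 4 values shown sit.

On these data alone, whether an amine, a methoxy group or a carboxylic acid at this carbon would stay close to compound 1 at 14000 nM remains open. As far as these compounds go, how ethyl and fluoro rank against each other also remains open.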